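The source may hold more compounds than are shown below. What is called first, only, known or untested is meant among the compounds shown, and "the series" means these compounds.

In a functional assay on A549 cells (Homo sapiens) for cytotoxicity, with a stated time of 48 h (on this read-out higher numbers stand for weaker inhibition and lower numbers for stronger inhibition), compound 3 `CCC(=O)Oc1ccc2oc(/C=C/[S+](C)[O-])cc(=O)c2c1` gives 2400 nM, within the scatter of compound 1 `CCOc1ccc2oc(/C=C/[S+](C)[O-])cc(=O)c2c1` at 1500 nM and compound 2 `CCCCOc1ccc2oc(/C=C/[S+](C)[O-])cc(=O)c2c1` at 1400 nM. Compound 4 `C[S+]([O-])/C=C/c1cc(=O)c2cc(Br)ccc2o1` follows from compound 3 by one change, bromo in place of propanoyloxy on an aromatic carbon. For the measured compounds named here, no measured compound carries bromo, so the evidence is indirect. The three measured steps at this place are all small and within the scatter: a 1.1-fold lower number from compound 1 to compound 2 (0.03 log units; within the scatter), a 1.6-fold higher number from compound 1 to compound 3 (0.20 log units; within the scatter) and a 1.7-fold higher number from compound 2 to compound 3 (0.23 log units; within the scatter). On that basis, no step beyond the scatter is expected in this assay, and the estimated step is a 1.5-fold lower number from compound 3 to compound 4 (0.18 log units; within the scatter). Compound 4 is expected to give about 1600 nM, with an estimated range of 600 nM to 4000 nM.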

Compound 4, half-maximal inhibitory concentration: 1100 nM
The estimate for compound 4 lay 1.5-fold (0.16 log units) above the measured number, within the range that was stated.
By their numbers in this assay, from the lowest: compounds 4, 2, 1 and 3 (each within the scatter of the next, the first and the last beyond it).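

For the compounds shown here, this position does not need an oxygen link for cytotoxicity: with bromo in place of propanoyloxy, this assay shows the first step here beyond the scatter (a 2.2-fold lower number from compound 3 to compound 4 (0.34 log units; beyond the scatter)). Bromo in place of butoxy (a 1.3-fold lower number from compound 2 to compound 4 (0.10 log units; within the scatter)) and in place of ethoxy (a 1.4-fold lower number from compound 1 to compound 4 (0.13 log units; within the scatter)) both stay within the scatter, so only propanoyloxy is set apart from bromo. Nothing measured here explains this difference. Still open, from the compounds shown here alone, is how an amine, a carboxylic acid or a chlorine atom would read at this position.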